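Compound 2 to compound 3: chloro removed

The source may hold more compounds than are shown below. What is called first, only, known or untested is meant among the compounds shown, and "the series" means these compounds.

Among the measured compounds shown here, compound 1 `Cc1nnc(SCC(=O)N/N=c2/scc(-c3ccccc3)n2-c2ccccc2)s1` and compound 2 `O=C(CSc1nnnn1-c1ccccc1)N/N=c1/scc(-c2ccc(Cl)cc2)n1-c1ccccc1` are the two measured members. In a functional assay on C6 cells (Rattus norvegicus) for cytotoxicity, read by MTT assay, with a stated time of 24 h (on this read-out higher numbers stand for weaker inhibition and lower numbers for stronger inhibition), compound 1 stops at the limit > 200 ug/mL, so no number is known. In this assay compound 2 likewise stops at the limit > 200 ug/mL. Compound 2 thus stands where both values sit, (the limit of > 200 ug/mL in this assay, at which 2 of the 2 values shown sit). Compound 3 `O=C(CSc1nnnn1-c1ccccc1)N/N=c1/scc(-c2ccccc2)n1-c1ccccc1` differs from compound 2 by hydrogen in place of chloro on an aromatic carbon. For the measured compounds named here, no measured step covers this change; in this assay the shift is expected to be none beyond the scatter, with the limit again probable. Compound 3 is expected at 250 ug/mL (range 120 ug/mL to 600 ug/mL), a step that the limit leaves unreadable from compound 2 to compound 3.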

Compound 3, half-maximal inhibitory concentration: 8.3 ug/mL
Compound 3: middle estimate off by 30-fold (1.48 log units), on the high side; the measured number lies below the stated range.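

In this assay, 4-chlorophenyl to phenyl turns a limit into a readable value, with an at least 24-fold lower number from compound 2 to compound 3 (1.38 log units; beyond the scatter). The group on the sulfur counts as well: 1-phenyl-1H-tetrazol-5-yl in place of 5-methyl-1,3,4-thiadiazol-2-yl gives an at least 24-fold lower number from compound 1 to compound 3 (1.38 log units; beyond the scatter). Of the three compounds, only compound 3 combines the phenyl with the tetrazolyl group, and both steps start from a limit, leaving their true size unknown: the limit of > 200 ug/mL in this assay, at which 2 of the 3 values shown sit.

As far as these compounds go, whether a fluoro or methoxy group at the chloro position would also keep a readable value remains open. So does the effect of an amine or carboxylic acid on the phenyl ring of compound 3.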